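Pentan-3-yl in place of tert-butyl on the shared core

This account rests on a few compounds, and the source may have more. Where it says the series, first, only, none or still open, it means among the compounds named here.

In a functional assay on FM3A cells (Mus musculus) for cytotoxicity (on this read-out higher numbers stand for an effect only at larger amounts of compound and lower numbers for an effect already at smaller amounts), compound 1 (`c1ccc(C2OOC3CCCC(c4ccccc4)(OO2)O3)cc1`) gives 50000 nM, compound 2 (`CCCCCCCC1OOC2CCCC(c3ccccc3)(OO1)O2`) gives 12000 nM and compound 3 (`CC(C)(C)C1OOC2CCCC(c3ccccc3)(OO1)O2`) gives 26000 nM. Two steps fix where compound 3 stands: a 1.9-fold lower number from compound 1 to compound 3 (0.28 log units; within the scatter), and a 2.2-fold higher number from compound 2 to compound 3 (0.34 log units; beyond the scatter). Its number therefore sits with the higher values of the three.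

Compound 4 (`CCC(CC)C1OOC2CCCC(c3ccccc3)(OO1)O2`) has not yet been measured. It carries pentan-3-yl in place of tert-butyl on a saturated ring carbon. Going by the values given here, no measured compound carries pentan-3-yl, so the evidence is indirect. Changes at this ring carbon have been small so far, the largest being a 4.2-fold lower number from compound 1 to compound 2 (0.62 log units; beyond the scatter), and the swap of heptyl for tert-butyl gave a 2.2-fold higher number from compound 2 to compound 3 (0.34 log units; beyond the scatter). With both groups being open-chain, a step beyond the scatter is not expected in this assay, and any drift is expected to be slightly downward. The expected step is a 1.2-fold lower number from compound 3 to compound 4 (0.09 log units; within the scatter). For compound 4 the estimated value is 21000 nM, with an expected range of 10000 nM to 42000 nM.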

Compound 4, half-maximal effective concentration: 33000 nM
The estimate for compound 4 lay 1.6-fold (0.20 log units) below the measured number; low and high end bracket the measured number.
By their numbers in this assay, from the lowest: compound 2; then compounds 3, 4 and 1 (each within the scatter of the next).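

In (this assay), pentan-3-yl in place of tert-butyl on this saturated ring carbon gives no step beyond the scatter (a 1.3-fold higher number from compound 3 to compound 4 (0.10 log units; within the scatter)), and the same holds for pentan-3-yl in place of phenyl (a 1.5-fold lower number from compound 1 to compound 4 (0.18 log units; within the scatter)), so compounds 1, 3 and 4 cannot be told apart on this read-out. Heptyl remains the only group at this position whose number separates from the others, and the gap now appears against pentan-3-yl as well (a 2.8-fold higher number from compound 2 to compound 4 (0.44 log units; beyond the scatter)). Nothing measured here accounts for this separation.

From the compounds shown here alone, whether a chain longer than heptyl would lower the number further remains open. Also open, going by these compounds, is whether an amine or a carboxylic acid at this ring carbon, or a replacement for the phenyl group on the other ring atom, would move the number at all.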